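A few compounds are considered here, and "the series" means these few. Any claim that something is new, unique, unknown or untested is made for them only; others in the source may bear on it.

The measured compounds:

Compound 1 `CCn1cc(-c2nc3ccc([N+](=O)[O-])cc3o2)c(=O)c2cc(F)c(N3CCNC(C)C3)c(F)c21` gives 900 nM in a functional assay on KB cells (Homo sapiens) for cytotoxicity, read by MTT assay; on this read-out lower numbers stand for stronger inhibition and higher numbers for weaker inhibition.
Compound 2 `CCn1cc(C(=O)Nc2cccc([N+](=O)[O-])c2)c(=O)c2cc(F)c(N3CCNC(C)C3)c(F)c21` gives 1700 nM in this assay.
Compound 3 `CCn1cc(C(=O)Nc2ccc(C(C)=O)cc2)c(=O)c2cc(F)c(N3CCNC(C)C3)c(F)c21` gives 42600 nM in this assay.

Compound 2 stands second highest of the three numbers: its nearest neighbour is compound 1, which lies within the scatter of it, and the furthest is compound 3, which sits well beyond the scatter. The step to the unmeasured compound 4 `CCn1cc(C(=O)NCc2ccc(OC)cc2)c(=O)c2cc(F)c(N3CCNC(C)C3)c(F)c21` alters the amide substituent: 4-methoxybenzyl in place of 3-nitrophenyl on an amide-type nitrogen. Going by the values given here, only one measured step bears on this position, the exchange of the aryl group on the same amide-type nitrogen, which gave a 25-fold higher number from compound 2 to compound 3 (1.40 log units; beyond the scatter). That step shows the group on this nitrogen matters strongly, and that a move away from the 3-nitrophenyl can cost a great deal. Among the compounds with values here, the change to 4-methoxybenzyl is at least as far-reaching, so a clear weakening beyond the scatter is expected, though with wide uncertainty since compound 3 is the only guide.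

Compound 4 is therefore estimated at 15000 nM in this assay, within a range of 4000 nM to 60000 nM. That estimate amounts to an expected 8.8-fold higher number from compound 2 to compound 4 (0.95 log units; beyond the scatter).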

Compound 4, half-maximal inhibitory concentration: 1630 nM
Beside the measured number, compound 4's estimate is 9.2-fold (0.96 log units) above it, and the stated range ends above it.
By their numbers in this assay, from the lowest: compounds 1, 4 and 2 (each within the scatter of the next); then compound 3.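

In this assay there is a 1.0-fold lower number from compound 2 to compound 4 (0.02 log units; within the scatter) and so 4-methoxybenzyl and 3-nitrophenyl on this amide-type nitrogen cannot be told apart, although the two groups differ in their atoms and in how the ring is attached. The other new step, a 26-fold lower number from compound 3 to compound 4 (1.42 log units; beyond the scatter) and it shows that the large loss seen with 4-acetylphenyl does not follow from every departure from 3-nitrophenyl, so this position accepts at least two quite different groups among the three shown. No measurement at hand explains why these groups give such different numbers.

The compounds shown leave open whether the benzyl part or the methoxy group of 4-methoxybenzyl counts for more, a question that plain benzyl and 4-methoxyphenyl on the same nitrogen would address. They also leave open how a carboxylic acid or an amine on the ring would fare here.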